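The compounds below may be only part of what the source reports. "The series", "measured", "known", "first", "only" and "open" are said of these compounds alone.

In a functional assay on NCI-H460 cells (Homo sapiens) for antiproliferative activity, read by MTT assay, with a stated time of 72 h (on this read-out lower numbers stand for stronger inhibition and higher numbers for weaker inhibition), compound 2 `CCNC(=O)c1cc(Oc2ccc(NC(=O)c3cc4cccnc4n(-c4ccc(F)cc4)c3=O)cc2)ccn1` gives 220 nM, the lowest number among the compounds with a result. Its nearest neighbour is compound 1 `CCNC(=O)c1cc(Oc2ccc(NC(=O)c3cc4cccnc4n(-c4ccccc4)c3=O)cc2)ccn1`, which gives 1120 nM in this assay, and the step of a 5.1-fold lower number from compound 1 to compound 2 (0.71 log units; beyond the scatter) lies between them. For compound 3 `CCNC(=O)c1cc(Oc2ccc(NC(=O)c3cc4cccnc4n(-c4ccc(Br)cc4)c3=O)cc2)ccn1` the entry in this assay reads "not determined" (no result reported), so no number is available for it. Compound 4 `CCCNC(=O)c1cc(Oc2ccc(NC(=O)c3cc4cccnc4n(-c4ccc(F)cc4)c3=O)cc2)ccn1` differs from compound 2 by a single change: methyl in place of hydrogen on a saturated chain carbon, two bonds along the chain from an amide-type nitrogen. Among the measured compounds shown here, the one measured step, a 5.1-fold lower number from compound 1 to compound 2 (0.71 log units; beyond the scatter), concerns a different part of the molecule, so no measured step bears on this change, and the data give no reason to expect a shift beyond the scatter. Compound 4 is therefore expected to give 220 nM in this assay, within a range from 100 nM to 500 nM. The expected step is no change at the digits printed from compound 2 to compound 4 (within the scatter).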

Compound 4, half-maximal inhibitory concentration: 120 nM
Estimate against measurement, compound 4: 1.8-fold (0.26 log units) above; low and high end bracket the measured number.
By their numbers in this assay, from the lowest: compounds 4 and 2 (each within the scatter of the next); then compound 1.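

Going from ethylamino to propylamino gives a 1.8-fold lower number from compound 2 to compound 4 (0.26 log units; within the scatter) in this assay. This is the first change shown on this chain, and it shows that one more carbon here leaves the number within the scatter, whereas the earlier step concerned a different part of the molecule. Nothing available explains this result.

Still open, going by these compounds, is whether a longer chain, such as butyl or hexyl, would also leave the number within the scatter. On these data alone, it is equally open how a branched isopropyl group, or an amine or carboxylic acid carried on the chain, would behave in place of propyl.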